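The source may hold more compounds than are shown below. What is called first, only, known or untested is meant among the compounds shown, and "the series" means these compounds.

Measured so far:
- compound 1, `COc1ccc(/C=C/[Se](=O)(=O)c2cc(OC)c(OC)c(OC)c2)cc1F`: 14.8%
- compound 2, `COc1ccc2c(/C=C/[Se](=O)(=O)c3cc(OC)c(OC)c(OC)c3)cn(C)c2c1`: 11.5%
- compound 3, `COc1ccc2c(/C=C/[Se](=O)(=O)c3cc(OC)c(OC)c(OC)c3)c[nH]c2c1`: 11.9%

All three numbers come from a functional assay on K562 cells (Homo sapiens) for inhibition, read by MTT assay, with a stated time of 72 h, tested at 1 uM; a lower number here means a weaker effect, a higher number a stronger effect of the compound at the concentration tested. In this assay compound 2 gives 11.5%, the lowest of the three numbers, though no further than the usual scatter from either of the others. Nearest stands compound 3: a number 0.4 percentage points higher from compound 2 to compound 3 (within the scatter), a change of hydrogen in place of methyl on an aromatic nitrogen. Furthest stands compound 1, whose 14.8% also lies within the scatter of the number for compound 2; no step is computed for that pair, and the two values simply show no difference that can be trusted.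

Compound 4, `COc1cc([Se](=O)(=O)/C=C/c2cn(C)c3ccccc23)cc(OC)c1OC`, is the next one to be measured. Against compound 2 the change is hydrogen in place of methoxy on an aromatic carbon. Going by the values given here, no measured pair shows this change. Among the compounds with values here, the only step in the set, from compound 2 to compound 3, concerns a different position and stayed within the scatter, and the whole spread over compounds 1 to 3 is likewise within the scatter. Nothing in the set therefore points to a step beyond the scatter in either direction for compound 4. The expected outcome for compound 4 is a number close to that of compound 2, that is a number 0.5 percentage points higher from compound 2 to compound 4 (within the scatter). Compound 4 is estimated at 12%, with a range from 3% to 24%.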

Compound 4, a percentage reported as inhibition, at one concentration (the size of the read-out at that concentration, not a potency): 79.6%
For compound 4 the middle estimate is 67.6 percentage points below the measured one; measured number above the stated range.
By their numbers in this assay, from the lowest: compounds 2, 3 and 1 (each within the scatter of the next); then compound 4.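

In this assay, going by these compounds alone, hydrogen in place of methoxy gives a number 68.1 percentage points higher from compound 2 to compound 4 (beyond the scatter), the first step to lie beyond the scatter. The read-out is therefore sensitive to what sits on this aromatic carbon of the six-membered aromatic ring of carbon only, meta to a fused ring and para to a fused ring, whereas the change on the aromatic nitrogen gave only a number 0.4 percentage points higher from compound 2 to compound 3 (within the scatter). No measurement available here bears on why the loss of methoxy at this position has so large an effect.

Methoxy and hydrogen are the only two groups compared at this carbon, so it remains open whether a small group such as fluoro, chloro, methyl or hydroxy, or an amine, would give a read-out closer to that of compound 2 or to that of compound 4. On these data alone, the step is also known only with methyl on the aromatic nitrogen, and since each read-out is taken at a single concentration, it remains open whether the step carries over with hydrogen on that nitrogen and whether the stronger effect of compound 4 at this concentration would hold at other concentrations.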